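Five-membered ring variants on the shared core

The compounds below may be only part of what the source reports. "The series", "measured", "known", "first", "only" and "open" are said of these compounds alone.

Measured compounds in a functional assay on Jurkat cells (Homo sapiens) for inhibition, read by MTT assay, with a stated time of 72 h; on this read-out higher numbers stand for weaker inhibition of growth and lower numbers for stronger inhibition of growth:
- compound 1 `COC(=O)c1nc(C)n(-c2ccc(C(F)(F)F)cc2)n1` gives 9100 nM
- compound 2 `COC(=O)c1nc(C2CCCCC2)n(-c2ccc(C(F)(F)F)cc2)n1` gives > 100000 nM, a limit of this assay and not a number
- compound 3 `COC(=O)c1nc(-c2ccoc2)n(-c2ccc(C(F)(F)F)cc2)n1` gives 97200 nM

Compound 3 holds the highest of the two numbers that are given as numbers; the nearest is compound 1, and the step of an 11-fold higher number from compound 1 to compound 3 (1.03 log units; beyond the scatter) is beyond the scatter. Compound 2 sits at the limit described under (the limit of > 100000 nM in this assay, at which 1 of the 3 values shown sits). The step of an at least 1.0-fold lower number from compound 2 to compound 3 (0.01 log units; that floor lies within the scatter) lies within the scatter, as far as a limit allows any comparison.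

Compound 4 `COC(=O)c1nc(-c2ccc[nH]2)n(-c2ccc(C(F)(F)F)cc2)n1` is not yet measured. It differs from compound 3 in one place: 1H-pyrrol-2-yl in place of furan-3-yl on an aromatic carbon. Going by the values given here, no measured step exchanges one five-membered aromatic ring for another at this carbon. Among the compounds with values here, the steps that bear on it are an at least 10-fold higher number from compound 1 to compound 2 (1.04 log units; beyond the scatter) and an 11-fold higher number from compound 1 to compound 3 (1.03 log units; beyond the scatter), both large and both in the direction of weaker growth inhibition when methyl gives way to a larger ring; cyclohexyl and furan-3-yl end up where the gap between them lies within the scatter. A pyrrole ring of the same size is therefore expected to stay in the same region, with no step beyond the scatter in this assay.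

Compound 4 is expected to give 90000 nM, with a range from 30000 nM to 160000 nM. The step of a 1.1-fold lower number from compound 3 to compound 4 (0.03 log units; within the scatter) is the estimate this implies, and a limit rather than a number is a real possibility for compound 4.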

Compound 4, concentration for 50% growth inhibition: > 100000 nM
Compound 4 gave a limit, no number (the forecaster's own chance of this, stated with the estimate: 40%); middle value at least 1.1-fold (0.04 log units) away from the limit.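

Compound 4 stands at a limit of this assay and not at a number: the limit of > 100000 nM in this assay, at which 2 of the 4 values shown sit.

With an at least 10-fold higher number from compound 1 to compound 4 (1.04 log units; beyond the scatter), a third ring group on this aromatic carbon, between two ring nitrogen atoms, lies beyond the scatter from methyl in the direction of weaker inhibition of growth, and none of the three compounds with a ring here goes against this. The exchange of furan-3-yl, with 1 hydrogen-bond acceptor, for 1H-pyrrol-2-yl, with 1 hydrogen-bond donor, gives an at least 1.0-fold higher number from compound 3 to compound 4 (0.01 log units; that floor lies within the scatter), so this swap of hetero atom and ring attachment shows no change that can be read, and the step between compound 2 and compound 4 cannot be read at all.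

Still open, as far as these compounds go, is whether a small group such as ethyl or an amine at this carbon would keep growth inhibition in the region of compound 1, which gives 9100 nM. The compounds shown also leave open how a carboxylic acid or an amide in place of the methoxycarbonyl group would read in this assay with methyl kept on this carbon.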